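This account rests on a few compounds, and the source may have more. Where it says the series, first, only, none or still open, it means among the compounds named here.

Among the measured compounds shown here, compound 1 `CNC(=O)/C=C/c1ccncc1-c1ccc2ccccc2c1` is the only compound here with a number: in an assay on a protein complex for inhibition of CDK8/Cyclin C (Homo sapiens), with a stated time of 1 h (on this read-out higher numbers stand for weaker inhibition and lower numbers for stronger inhibition), compound 1 gives 12.4 nM. Compound 2 `O=C(O)COc1ccncc1-c1ccc2ccccc2c1` was also made, but in this assay compound 2 gives "not determined" (no result reported), so it offers no comparison. Compound 3 `O=C(O)CCNC(=O)/C=C/c1ccncc1-c1ccc2ccccc2c1` differs from compound 1 in one place: carboxymethyl in place of hydrogen on a saturated chain carbon bound to an amide-type nitrogen. For the measured compounds named here, no measured pair in this set shows such a change, so the size of the step is open. A small step toward weaker inhibition, close to the scatter, is expected, estimated as a 2.0-fold higher number from compound 1 to compound 3 (0.30 log units; within the scatter). For compound 3 the expected value is 25 nM, within a range from 8 nM to 80 nM.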

Compound 3, half-maximal inhibitory concentration: 870 nM
Compound 3: middle estimate off by 35-fold (1.54 log units), on the low side; the measured number lies above the stated range.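

In this assay the change from methylcarbamoyl to (2-carboxyethyl)carbamoyl gives a 70-fold higher number from compound 1 to compound 3 (1.85 log units; beyond the scatter) and so clearly weakens inhibition. This position is therefore sensitive to what is attached there, which a single measured compound could not show. Nothing available here explains the loss. Going by these compounds, it remains open whether the longer chain or its carboxylic acid end accounts for the change. A plain propyl group or a 2-aminoethyl group on the same nitrogen would help separate these two parts.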